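The source may hold more compounds than are shown below. What is called first, only, known or untested is meant among the compounds shown, and "the series" means these compounds.

Measured compounds in a functional assay on SK-BR-3 cells (Homo sapiens) for antiproliferative activity, read by MTT assay, with a stated time of 72 h; on this read-out higher numbers stand for weaker inhibition and lower numbers for stronger inhibition:
compound 1 `C/C=C1/[C@H](O[C@@H]2O[C@H](CO)[C@@H](O)[C@H](O)[C@H]2O)OC=C(C(=O)OC)[C@H]1CC(=O)OCCCc1ccc(OC)c(OC)c1`: > 20000 nM
compound 2 `C/C=C1/[C@H](O[C@@H]2O[C@H](CO)[C@@H](O)[C@H](O)[C@H]2O)OC=C(C(=O)OC)[C@H]1CC(=O)OCCC1CCCCC1`: 2000 nM
compound 3 `C=C(C)CCOC(=O)C[C@@H]1C(C(=O)OC)=CO[C@@H](O[C@@H]2O[C@H](CO)[C@@H](O)[C@H](O)[C@H]2O)/C1=C/C`: > 15000 nM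

In this assay compound 2 gives a measured number. Compound 3 stands only at a limit of the assay, as the limit of > 15000 nM in this assay, at which 1 of the 3 values shown sits, shows. Compound 1 likewise sits at a limit, (the limit of > 20000 nM in this assay, at which 1 of the 3 values shown sits). Among the compounds with values here, the step of an at least 7.5-fold higher number from compound 2 to compound 3 (0.87 log units; beyond the scatter) is the one readable step reaching compound 3, while a step that the two limits leave unreadable from compound 1 to compound 3 cannot be sized. Compound 4 `C/C=C1/[C@H](O[C@@H]2O[C@H](CO)[C@@H](O)[C@H](O)[C@H]2O)OC=C(C(=O)OC)[C@H]1CC(=O)OCCCC` differs from compound 3 by ethyl in place of 1-methylethenyl on a saturated chain carbon, two bonds along the chain from an oxygen next to a carbonyl group. Within the data shown here, no measured step swaps 1-methylethenyl for ethyl, so the expectation rests on compound 3 standing at a limit and on cyclohexyl in compound 2 alone giving a measured number. Compound 4 is therefore expected to remain near that limit, with a number no higher from compound 3 to compound 4 (the limit leaves the size open) expected to be small. Compound 4 is estimated at 15000 nM, expected between 4000 nM and 50000 nM.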

Compound 4, half-maximal inhibitory concentration: > 15000 nM
Compound 4: no number, only a limit; the forecaster's own chance of this, stated with the estimate: 60%; the middle value sits exactly at the limit.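

In this assay compound 4 gives only a limit, not a number: the limit of > 15000 nM in this assay, at which 2 of the 4 values shown sit. Within the data shown here, exchanging 1-methylethenyl for saturated ethyl therefore does not restore a measured number, and cyclohexyl remains the only group here that gives one, with an at least 7.5-fold higher number from compound 2 to compound 4 (0.87 log units; beyond the scatter). The steps from compound 3 and compound 1 to compound 4 cannot be read, since both ends are limits.

The compounds shown leave open what numbers lie behind these limits. They also leave open whether a longer chain such as hexyl, or a cyclopentyl ring, would give a measured number at this place.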